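The source may hold more compounds than are shown below. What is called first, only, known or untested is meant among the compounds shown, and "the series" means these compounds.

Series notes. Compound 1 `O=C1C=C(Nc2ccccc2)C(=O)c2c1nc1n2[C@H]2OC[C@@H](O)[C@H]2OC1` gives in a functional assay on HeLa cells (Homo sapiens) for inhibition, read by sulforhodamine B assay (a lower number here means a stronger inhibitor, a higher number a weaker inhibitor), a value of 5620 nM. For the measured compounds named here, compound 2 `O=C1C=C(Nc2cccc(Cl)c2)C(=O)c2c1nc1n2[C@H]2OC[C@@H](O)[C@H]2OC1` gives 6040 nM; the step of a 1.1-fold higher number from compound 1 to compound 2 (0.03 log units; within the scatter) leaves the two within the scatter of each other, so compound 2 and compound 1 stand together on the numbers so far. Compound 3 `O=C1C=C(N2CCCCC2)C(=O)c2c1nc1n2[C@H]2OC[C@@H](O)[C@H]2OC1` carries the change (piperidin-1-yl in place of (3-chlorophenyl)amino on a double-bonded ring carbon). Going by the values given here, no measured step touches this kind of exchange; the single step of a 1.1-fold higher number from compound 1 to compound 2 (0.03 log units; within the scatter) concerns only a substituent on the ring that now leaves, so it offers no direct guide. The estimate for compound 3 is therefore a step of a 1.3-fold higher number from compound 2 to compound 3 (0.12 log units; within the scatter), expected around 8000 nM with a range of 2500 nM to 25000 nM.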

Compound 3, half-maximal inhibitory concentration: > 16000 nM
Compound 3: no number, only a limit; the forecaster's own chance of this, stated with the estimate: 10%; middle value at least 2.0-fold (0.30 log units) from the limit.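

In this assay compound 3 has a limit, not a number: the limit of > 16000 nM in this assay, at which 1 of the 3 values shown sits.

Exchange at the double-bonded ring carbon nevertheless registers, with an at least 2.6-fold higher number from compound 2 to compound 3 (0.42 log units; beyond the scatter) and an at least 2.8-fold higher number from compound 1 to compound 3 (0.45 log units; beyond the scatter), whereas the chloro exchange on the anilino ring gave only a 1.1-fold higher number from compound 1 to compound 2 (0.03 log units; within the scatter). Going by these compounds, replacing either aromatic amino group with piperidin-1-yl therefore weakens inhibition, though the true size of both steps stays unknown.

The exchange alters the ring and removes the hydrogen-bond donor together, so the compounds shown cannot separate the two. On these data alone, whether benzylamino, which keeps the amino hydrogen on a non-aromatic link, or morpholin-4-yl would behave like compound 1 or compound 3 remains open.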